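The source may hold more compounds than are shown below. What is called first, only, known or untested is meant among the compounds shown, and "the series" means these compounds.

Compound 1 (`COc1cc(-c2nn(-c3cccc(NC(=O)Nc4cc(C(F)(F)F)cc(C(F)(F)F)c4)c3)cc2-c2ccncc2)ccc1Cl`) is the reference point. For the measured compounds named here, in a functional assay on NCI-H23 cells (Homo sapiens) for inhibition, read by sulforhodamine B assay, with a stated time of 48 h (on this read-out higher numbers stand for lower toxicity in this test and lower numbers for higher toxicity in this test), compound 1 gives 29600 nM as the only true number among the three compounds measured so far. Compound 2 (`COc1cc(-c2nn(-c3cccc(NC(=O)c4cccc(C(F)(F)F)c4)c3)cc2-c2ccncc2)ccc1Cl`) shows > 50000 nM as a limit of the assay, not a number. Compound 3 (`COc1cc(-c2nn(-c3cccc(NC(=O)Nc4ccc(Cl)c(Cl)c4)c3)cc2-c2ccncc2)ccc1Cl`) likewise shows > 50000 nM as a limit, not a number. Most of the picture therefore consists of the limit of > 50000 nM in this assay, at which 2 of the 3 values shown sit, and little else. Going by the values given here, the one measured step between close relatives is a step that the two limits leave unreadable from compound 2 to compound 3 and has no size to carry over.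

Compound 4 (`COc1cc(-c2nn(-c3cccc(NC(=O)Nc4cccc(C(F)(F)F)c4)c3)cc2-c2ccncc2)ccc1Cl`) differs from compound 1 by a single change, hydrogen in place of trifluoromethyl on an aromatic carbon. Among the compounds with values here, no measured step isolates this change. The expectation therefore rests on compound 1 alone, which stands at 29600 nM. Only a modest rise in the number, toward lower toxicity, or none beyond the scatter is expected in this assay for this change. The estimated move is a 1.4-fold higher number from compound 1 to compound 4 (0.15 log units; within the scatter). For compound 4 the expected value is 42000 nM (estimated range from 24000 nM to 50000 nM).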

Compound 4, concentration lethal to 50% of the cells: > 50000 nM
Compound 4: only a limit was reported; the forecaster's own chance of this, stated with the estimate: 50%; middle value at least 1.1-fold (0.07 log units) from the limit.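

For the compounds shown here, compound 1 and compound 4 form the first pair in this set that differs in one place and gives a step with a direction. In this assay, hydrogen in place of trifluoromethyl on an aromatic carbon, meta to a trifluoromethyl group, gives an at least 1.6-fold higher number from compound 1 to compound 4 (0.22 log units; that floor lies within the scatter), so the move points toward lower toxicity in this test, though its printed floor does not by itself clear the usual scatter. The steps linking compound 2, compound 3 and compound 4 cannot be read, because each of these compounds has only a limit, which leaves compound 1 as the single true number in the set: the limit of > 50000 nM in this assay, at which 3 of the 4 values shown sit.

Going by these compounds, the real size of the step remains open, since compound 4 has a limit rather than a number, and a single pair cannot show whether the same change would act alike on another compound. It is also unknown how a methyl group, a methoxy group, an amine or a carboxylic acid on this same aromatic carbon would compare with hydrogen and trifluoromethyl in this assay.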